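Moving the Methyl Back Into a Straight Chain

This account rests on a few compounds, and the source may have more. Where it says the series, first, only, none or still open, it means among the compounds named here.

Compound 1 `CCCCCC(=O)OCC(C)(C)CC1=C(O)C(=O)c2ccccc2C1=O`: 169000 nM
Compound 2 `CCCCCCCC(=O)OCC(C)(C)CC1=C(O)C(=O)c2ccccc2C1=O`: > 258000 nM (a limit of the assay, not a number)
Compound 3 `CCCCCCC(C)C(=O)OCC(C)(C)CC1=C(O)C(=O)c2ccccc2C1=O`: 450 nM

In an ADME assay on Vero cells (Chlorocebus sabaeus) for cytotoxicity, read by reporter gene assay, with a stated time of 4 days (on this read-out higher numbers stand for weaker inhibition and lower numbers for stronger inhibition), compound 3 gives 450 nM, the lowest number of the three. Compound 2 has only a limit, > 258000 nM, and no exact number. Compound 4 `CCCCCCCCC(=O)OCC(C)(C)CC1=C(O)C(=O)c2ccccc2C1=O` has not yet been measured. It differs from compound 3 in one place: octyl in place of 1-methylheptyl on a carbonyl carbon, with octyl in place of 1-methylheptyl on a carbonyl carbon.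

Within the data shown here, three measured steps bear on this change. The first, an at least 1.5-fold higher number from compound 1 to compound 2 (0.18 log units; that floor lies within the scatter), shows no separation between those two compounds. The other two, a 380-fold lower number from compound 1 to compound 3 (2.57 log units; beyond the scatter) and an at least 570-fold lower number from compound 2 to compound 3 (2.75 log units; beyond the scatter), are both large. Compound 3 is therefore the outlier of the set, and compound 4 loses the 1-methylheptyl group found only in compound 3. A large step towards a higher number is thus expected in this assay, though three compounds make a thin basis. The expected change is a 330-fold higher number from compound 3 to compound 4 (2.52 log units; beyond the scatter). For compound 4 the estimated value is 150000 nM, with an expected range from 30000 nM to 400000 nM.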

Compound 4, half-maximal inhibitory concentration: 150000 nM
Compound 4: the middle estimate sits on the measured number at the digits printed; the range from low to high includes it.
By their numbers in this assay, from the lowest: compound 3; then compounds 4 and 1 (each within the scatter of the next). At a limit, above all of these: compound 2.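

Octyl and 1-methylheptyl have the same atom count, yet in this assay putting octyl in place of 1-methylheptyl on this carbonyl carbon gives a 330-fold higher number from compound 3 to compound 4 (2.52 log units; beyond the scatter), so how the chain is joined matters here, not just its size. The straight-chain compound 4 shows no separation from its shorter relative, with a 1.1-fold lower number from compound 1 to compound 4 (0.05 log units; within the scatter). Compound 2 has a limit and not a number, so an at least 1.7-fold lower number from compound 2 to compound 4 (0.23 log units; that floor lies within the scatter) does not separate it from compound 4: the limit of > 258000 nM in this assay, at which 1 of the 4 values shown sits.

Only compound 3 carries a branched chain, so one example cannot show whether branching on this carbon generally lowers the number. A shorter branched group such as 1-methylpropyl, or a chain ending in a carboxylic acid, would probe this position further.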